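A few compounds are considered here, and "the series" means these few. Any claim that something is new, unique, unknown or untested is made for them only; others in the source may bear on it.

Measured compounds in the series:
- compound 1, `CCCN(CCC)c1ccc(Nc2ncc(Cl)c(Oc3cccc(NC(=O)CC)c3)n2)cc1`: "not active" (no number reported)
- compound 2, `CCC(=O)Nc1cccc(Oc2nc(Nc3ccc(N(CC)CC)cc3)ncc2Cl)c1`: 21.2%

In an assay on isolated protein for inhibition of NUAK family SNF1-like kinase 2 (Homo sapiens), read by ADP-Glo, with a stated time of 60 min, tested at 10 uM, in the presence of a further agent that is not named here (on this read-out higher numbers stand for more inhibition at the one concentration tested (going by the name of the read-out) and lower numbers for less inhibition), compound 1 is reported as "not active" (no number reported) without a number, while compound 2 gives 21.2%. Compound 2 therefore stands on the only number shown for the series; the single other entry carries no figure, so no ordering among the measured compounds can be drawn from these two results beyond noting that compound 2 shows measurable inhibition at the concentration tested.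

Compound 3, `CCC(=O)Nc1cccc(Oc2nc(Nc3ccc(N(C)C)cc3)ncc2Cl)c1`, has not yet been measured. It differs from compound 2 in one place only: dimethylamino in place of diethylamino on an aromatic carbon. Dimethylamino enters on the aromatic carbon where diethylamino stood in compound 2, para to a large group.

Among the compounds with values here, no step between two measured compounds is available for this kind of change, so the size of the step in this assay cannot be read from the data. Given that the change is confined to two carbon atoms of an amine substituent, the step is expected to stay within the usual scatter, with no clear direction. The expected step is a number 0.8 percentage points higher from compound 2 to compound 3 (within the scatter). Compound 3 is estimated to give 22%, with a range from 6% to 40%.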

Compound 3, a percentage reported as inhibition, at one concentration (the size of the read-out at that concentration, not a potency): 31.7%
The estimate for compound 3 lay 9.7 percentage points below the measured number; low and high end bracket the measured number.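

In this assay, within the data shown here, dimethylamino in place of diethylamino on the aromatic carbon, para to a large group, gives a number 10.5 percentage points higher from compound 2 to compound 3 (beyond the scatter) and is the first readable step. This position therefore responds to the alkyl groups on the amine, with the higher number going to the group of 3 heavy atoms rather than the group of 5; compound 1, with dipropylamino at the same place, gives "not active" (no number reported) and fits that order without adding a second step of known size. No measured information on the reason for this step is at hand.

What the compounds shown leave open is whether the order holds beyond these three amines, since a methylamino group, a free amino group, or a ring amine such as pyrrolidine or morpholine at this position could continue it or break it. Each result also comes from one concentration, so the step describes inhibition at that concentration and leaves the potency of compound 3 unsettled.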